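Swapping dihydroxyphenyl for dimethoxyphenyl in a second series

The source may hold more compounds than are shown below. What is called first, only, known or untested is meant among the compounds shown, and "the series" means these compounds.

Of the compounds shown here, three have been tested in a functional assay on RS4-11 cells (Homo sapiens) for inhibition, read by CCK-8 assay, with a stated time of 48 h; a lower number here means a stronger inhibitor, a higher number a weaker inhibitor. Compound 1 `COc1ccc(Oc2ccc(C(C)C)cc2-c2ccsc2S(=O)(=O)NCCNC(=S)Nc2ccc([N+](=O)[O-])cc2)cc1OC` gives 5800 nM, compound 2 `O=C(Nc1cccc([N+](=O)[O-])c1)N1CCN(S(=O)(=O)c2sccc2-c2ccccc2Oc2ccc(O)c(O)c2)CC1` gives 9800 nM, and compound 3 `CC(C)c1ccc(Oc2ccc(O)c(O)c2)c(-c2ccsc2S(=O)(=O)NCCNC(=S)Nc2ccc([N+](=O)[O-])cc2)c1` gives 5100 nM. Compound 1 and compound 3 differ in one place: 3,4-dimethoxyphenyl in place of 3,4-dihydroxyphenyl on an oxygen on an aromatic ring. That change gave a 1.1-fold higher number from compound 3 to compound 1 (0.06 log units; within the scatter). The same change now separates compound 2 from the unmeasured compound 4 `COc1ccc(Oc2ccccc2-c2ccsc2S(=O)(=O)N2CCN(C(=O)Nc3cccc([N+](=O)[O-])c3)CC2)cc1OC`: 3,4-dimethoxyphenyl in place of 3,4-dihydroxyphenyl on an oxygen on an aromatic ring. The difference between the core of compound 2 and the core of compound 3 is not broken down here. Because the earlier change produced only a 1.1-fold higher number from compound 3 to compound 1 (0.06 log units; within the scatter), a similar step is expected here, so for compound 4 the estimated step is a 1.1-fold higher number from compound 2 to compound 4 (0.03 log units; within the scatter). In this assay compound 4 is therefore expected to give about 10500 nM, most likely between 5000 nM and 22000 nM.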

Compound 4, half-maximal inhibitory concentration: > 50000 nM
Compound 4 gave a limit, no number; the forecaster's own chance of this, stated with the estimate: 10%; at least 4.7-fold (0.67 log units) between middle value and limit.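

In this assay compound 4 gives > 50000 nM, which is a limit of the assay and not a number. Putting 3,4-dimethoxyphenyl in place of 3,4-dihydroxyphenyl gave an at least 5.1-fold higher number from compound 2 to compound 4 (0.70 log units; beyond the scatter), and the change did not carry the same size of step from one core to the other: the same change on two cores in this assay, a 1.1-fold higher number (0.06 log units; within the scatter) from compound 3 to compound 1 and an at least 5.1-fold higher number (0.70 log units; beyond the scatter) from compound 2 to compound 4, at least 4.4-fold (0.65 log units) apart, beyond the scatter of two such steps This shows that the earlier step could not be transferred to the core of compound 2, but it does not show the full size of the new step or which part of the core matters: the limit of > 50000 nM in this assay, at which 1 of the 4 values shown sits.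

Only two cores carrying this change are shown, and its effect on any other core remains open. Also open, on these data alone, is how a carboxylic acid or an amine in place of these two groups, on the same oxygen, would behave.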